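Tert-butyl for methyl on the benzyl ring of compound 2

A few compounds are considered here, and "the series" means these few. Any claim that something is new, unique, unknown or untested is made for them only; others in the source may bear on it.

Compound 1 `Nc1cccc(/C=C2\SC(=O)N(Cc3ccc(F)cc3)C2=O)c1` gives 87000 nM in a functional assay on CCRF-CEM cells (Homo sapiens) for cytotoxicity, read by cell counting, with a stated time of 3 days; a higher number here means a weaker inhibitor, a lower number a stronger inhibitor. Compound 2 `C=C(Br)C(=O)Nc1cccc(/C=C2\SC(=O)N(Cc3ccc(C)cc3)C2=O)c1` gives 1200 nM in this assay. Compound 3 `Cc1ccc(CN2C(=O)S/C(=C\c3cccc(N)c3)C2=O)cc1` gives only a limit of the assay in this assay, namely > 250000 nM.

Compound 2 holds the lowest of the two plain numbers; compound 1 sits an at least 200-fold higher number from compound 2 to compound 3 (2.31 log units; beyond the scatter) away in the weaker direction, and the third value, that of compound 3, is a limit (the limit of > 250000 nM in this assay, at which 1 of the 3 values shown sits). The new compound 4 `C=C(Br)C(=O)Nc1cccc(/C=C2\SC(=O)N(Cc3ccc(C(C)(C)C)cc3)C2=O)c1` differs from compound 2 in one place: tert-butyl in place of methyl on an aromatic carbon.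

Going by the values given here, two measured steps touch this series. an at least 200-fold higher number from compound 2 to compound 3 (2.31 log units; beyond the scatter) shows how much the (1-bromoethenyl)carbonyl group matters, but compound 4 keeps it. an at least 2.8-fold higher number from compound 1 to compound 3 (0.45 log units; beyond the scatter) is the only step at the benzyl ring carbon itself, and it goes from fluoro to methyl, not from methyl to tert-butyl, so it bears on the position but not on the group. With no direct evidence, the step of a 1.3-fold higher number from compound 2 to compound 4 (0.10 log units; within the scatter) is expected to stay within the usual scatter. Compound 4 is therefore estimated at 1500 nM, with a range of 400 nM to 6000 nM.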

Compound 4, half-maximal inhibitory concentration: 3000 nM
Compound 4: the middle estimate sits 2.0-fold (0.30 log units) below what was measured; the measured number falls inside the stated range.
By their numbers in this assay, from the lowest: compound 2; then compound 4; then compound 1. At a limit, above all of these: compound 3.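

In this assay, going from 4-methylphenyl to 4-(tert-butyl)phenyl gives a 2.5-fold higher number from compound 2 to compound 4 (0.40 log units; beyond the scatter), a modest step that lies beyond the scatter. Going by these compounds alone, until now, the only step at this aromatic carbon ran from fluoro to methyl and ended at a limit, whereas here the (1-bromoethenyl)carbonyl group stays in place and both compounds give plain numbers, so the change at this carbon can be sized directly: it costs some activity, yet compound 4 still gives a plain number. Nothing measured among these compounds explains why the number rises with this change.

The compounds shown leave open how an ethyl group, a methoxy group or an amine would read at this carbon with the (1-bromoethenyl)carbonyl group kept. They also leave open whether fluoro, seen so far only on the compound with the free amine, would read differently from methyl with that group in place.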